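The source may report more compounds than this note shows. Statements on the series, on what has been measured and on what is new or still open speak of the compounds shown alone.

In a functional assay on HL-60 cells (Homo sapiens) for inhibition, read by MTT assay, with a stated time of 72 h (a lower number here means a stronger inhibitor, a higher number a weaker inhibitor), compound 1 `COc1ccc(Cl)cc1N1CCN(C(=O)c2oc(C)nc2-c2ccccc2F)CC1` gives 153 nM. Compound 2 `COc1ccc(-c2nc(C)oc2C(=O)N2CCN(c3cccc(Cl)c3)CC2)cc1O` stands at "not active" (no number reported), so it offers no single number to measure from. Compound 3 `Cc1nc(-c2ccccc2F)c(C(=O)N2CCN(c3cccc(Cl)c3)CC2)o1` has yet to be tested. The structural change is 2-fluorophenyl in place of 3-hydroxy-4-methoxyphenyl on an aromatic carbon, next to the ring nitrogen. With no number for compound 2, the size of this step in this assay cannot be stated, but its direction can be expected: toward a stronger inhibitor with a measurable value. The entering 2-fluorophenyl is also carried by compound 1. Compound 1 gives 153 nM. That single compound is thin support, and a second result without a number remains possible. For compound 3, the estimated value in this assay is 300 nM, with an expected range from 60 nM to 1500 nM.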

Compound 3, half-maximal inhibitory concentration: 39.4 nM
Beside the measured number, compound 3's estimate is 7.6-fold (0.88 log units) above it, outside the stated range (below it).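

In this assay the exchange of 3-hydroxy-4-methoxyphenyl for 2-fluorophenyl turns a compound without a number into one with a measured potency, so activity at this ring carbon depends on the group it carries, though the size of that step cannot be read. The methoxy of compound 1 also proves unnecessary for activity, as hydrogen in its place gives a 3.9-fold lower number from compound 1 to compound 3 (0.59 log units; beyond the scatter) and keeps the 2-fluorophenyl group unchanged. No measured evidence explains either change.

The compounds shown do not separate the contributions of the hydroxy, the methoxy and the fluorine, which change together between compound 2 and compound 3. On these data alone, how an unsubstituted phenyl, a 3-hydroxyphenyl or an aminophenyl would behave on the same ring carbon remains open.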